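A few compounds are considered here, and "the series" means these few. Any claim that something is new, unique, unknown or untested is made for them only; others in the source may bear on it.

Compound 3 `CCN(CC)c1ccc2cc(C(=O)c3ccc(N4CCN(C(=O)CN5CCN(Cc6ccc(C(F)(F)F)cc6)CC5)CC4)cc3)oc2c1` carries a 4-(trifluoromethyl)benzyl group on the amine nitrogen of its terminal ring. In a functional assay on HCT-116 cells (Homo sapiens) for cytotoxicity, read by MTT assay, with a stated time of 48 h (on this read-out higher numbers stand for weaker inhibition and lower numbers for stronger inhibition), compound 3 gives > 40000 nM, which is a limit of the assay rather than a number. Compound 1 `CCN(CC)c1ccc2cc(C(=O)c3ccc(N4CCN(C(=O)CN5CCN(C(=O)CCl)CC5)CC4)cc3)oc2c1`, with a (chloromethyl)carbonyl group at the same nitrogen, gives > 40000 nM in this assay, again a limit. Compound 2 `CCN(CC)c1ccc2cc(C(=O)c3ccc(N4CCN(C(=O)CN5CCN(Cc6ccc(/C=C/C(=O)OC)cc6)CC5)CC4)cc3)oc2c1` gives 9920 nM in this assay. The step that the two limits leave unreadable from compound 1 to compound 3 cannot be read because the limit of > 40000 nM in this assay, at which 2 of the 3 values shown sit, caps both values. The step of an at least 4.0-fold higher number from compound 2 to compound 3 (0.60 log units; beyond the scatter) is readable and moves toward weaker inhibition. Compound 4 `CCOC(=O)CN1CCN(CC(=O)N2CCN(c3ccc(C(=O)c4cc5ccc(N(CC)CC)cc5o4)cc3)CC2)CC1` is made by the change (ethoxycarbonyl in place of 4-(trifluoromethyl)phenyl on a saturated chain carbon bound to an amine nitrogen in a ring). Among the measured compounds shown here, of the measured steps, both touch the same nitrogen-bound group: the replacement of an aromatic-bearing group by a short non-aromatic one in compound 1 leaves the limit in place, and the aromatic substituent change in compound 2 is the only one that moves the number. Compound 4 is therefore expected to stay near the limit, with an estimated step of a number no higher from compound 3 to compound 4 (the limit leaves the size open) and an estimated value of 40000 nM, ranging from 15000 nM to 100000 nM.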

Compound 4, half-maximal inhibitory concentration: > 40000 nM
Compound 4 ended at the assay's limit; the forecaster's own chance of this, stated with the estimate: 65%; the middle value lies on the limit itself.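

Swapping 4-(2-(methoxycarbonyl)ethenyl)phenyl for ethoxycarbonyl on this saturated chain carbon gives, in this assay, an at least 4.0-fold higher number from compound 2 to compound 4 (0.60 log units; beyond the scatter). Compound 4 keeps an ester, as compound 2 does, yet its value is still a limit, so among the compounds shown, an ester without the phenyl and ethenyl parts is not enough to give a measurable value. The steps from compound 3 to compound 4 and from compound 1 to compound 4 cannot be read, because both values in each pair are capped: the limit of > 40000 nM in this assay, at which 3 of the 4 values shown sit.

Going by these compounds, it remains open whether the phenyl ring, the ethenyl link or the ester at its end matters most in compound 2. Also open, on these data alone, is how a carboxylic acid or an amine at the end of that group would read.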